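Swapping methoxy for chloro beside the methylsulfonyl group

A few compounds are considered here, and "the series" means these few. Any claim that something is new, unique, unknown or untested is made for them only; others in the source may bear on it.

Measured compounds:
- compound 1, `CS(=O)(=O)c1cc(C(=O)N=C(N)N)c(Cl)cc1Cl`: 140 nM
- compound 2, `CS(=O)(=O)c1cc(C(=O)N=C(N)N)ccc1C#N`: 140 nM
- compound 3, `COc1ccc(C(=O)N=C(N)N)cc1S(C)(=O)=O`: 270 nM

All three share a core carrying an acylguanidine and a methylsulfonyl group, and were tested in a functional assay for inhibition of sodium/hydrogen exchanger (Oryctolagus cuniculus); a higher number here means a weaker inhibitor, a lower number a stronger inhibitor. Compound 3 gives the largest number of the three, yet its gaps to compound 1 and to compound 2 are both within the scatter, so no real order can be read among them.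

Compound 4, `CS(=O)(=O)c1cc(C(=O)N=C(N)N)ccc1Cl`, differs from compound 3 by chloro in place of methoxy on an aromatic carbon. Among the measured compounds shown here, only one measured step bears on this position: a 1.9-fold higher number from compound 2 to compound 3 (0.29 log units; within the scatter), a change at the same carbon that stayed inside the scatter. Compound 1 also carries chloro at that carbon, but with a second chloro elsewhere, so its value shows only that such a chloro is compatible with a number near that of compound 3.

The step from compound 3 to compound 4 is therefore expected to be small, a 1.5-fold lower number from compound 3 to compound 4 (0.18 log units; within the scatter), with no clear direction beyond the scatter. Compound 4 is estimated at 180 nM, within 80 nM to 400 nM.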

Compound 4, half-maximal inhibitory concentration: 380 nM
The estimate for compound 4 lay 2.1-fold (0.32 log units) below the measured number; measured number inside the range.
By their numbers in this assay, from the lowest: compounds 1, 2, 3 and 4 (each within the scatter of the next, the first and the last beyond it).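

At the aromatic carbon ortho to a methylsulfonyl group, this assay does not separate chloro from methoxy, since that swap gives a 1.4-fold higher number from compound 3 to compound 4 (0.15 log units; within the scatter) and stays inside the usual noise. Chloro in place of cyano at the same carbon gives a 2.7-fold higher number from compound 2 to compound 4 (0.43 log units; beyond the scatter) and is the first step at this position to pass the scatter, so the group there can matter, though only modestly so far. Hydrogen in place of the second chloro, at a different carbon, gives a 2.7-fold higher number from compound 1 to compound 4 (0.43 log units; beyond the scatter) and shows that this other position can also shift the number modestly.

Going by these compounds, whether an amine or a carboxylic acid at the carbon ortho to the methylsulfonyl group would keep the number in this range remains open. Nothing available gives a reason for any of these steps.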